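The source may hold more compounds than are shown below. What is called first, only, known or untested is meant among the compounds shown, and "the series" means these compounds.

In a functional assay on CHO cells for agonist activity at muscarinic acetylcholine receptor M5 (Rattus norvegicus) (a lower number here means that less compound is needed, a higher number that more compound is needed for the effect), compound 1 `CCOC(=O)N1CCC(N2CCC[C@@H](NC(=O)C3CCCCC3)C2)CC1` gives only a limit of the assay, > 10000 nM. Compound 2 `CCOC(=O)N1CCC(N2CCC[C@@H](NC(=O)c3ccccc3Cl)C2)CC1` likewise gives only a limit in this assay, > 10000 nM. The step that the two limits leave unreadable from compound 1 to compound 2 therefore cannot be read, as both values sit at the same limit, (the limit of > 10000 nM in this assay, at which 2 of the 2 values shown sit). On the numbers shown, compound 2 thus stands at the limit of this assay, without a measurable value of its own.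

Compound 3 `CCOC(=O)N1CCC(N2CCC[C@@H](NC(=O)c3ccc(C)cc3)C2)CC1` differs from compound 2 in one place: 4-methylphenyl in place of 2-chlorophenyl on a carbonyl carbon. Among the compounds with values here, no measured step gives a direct reading on this change; the only step between measured compounds, a step that the two limits leave unreadable from compound 1 to compound 2, is itself unreadable, so no size can be taken from it. Since compound 1 and compound 2 both sit at the limit (the limit of > 10000 nM in this assay, at which 2 of the 2 values shown sit), the expectation for compound 3 is that it stays near that limit in this assay, with no step beyond the scatter expected. The step that the limit leaves unreadable from compound 2 to compound 3 is expected to be essentially flat. The estimate for compound 3 in this assay is 15000 nM, with a range from 5000 nM to 50000 nM.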

Compound 3, half-maximal effective concentration: > 10000 nM
Compound 3 gave a limit, no number; the forecaster's own chance of this, stated with the estimate: 80%; the middle value does not contradict the limit.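

Compound 3, like compound 1 and compound 2, gives only a limit in this assay, so no step among these three compounds can be read: the limit of > 10000 nM in this assay, at which 3 of the 3 values shown sit.

The compounds shown leave open whether any group on the carbonyl carbon brings a measurable value in this assay, and how cyclohexyl, 2-chlorophenyl and 4-methylphenyl would then rank.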